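This account rests on a few compounds, and the source may have more. Where it says the series, first, only, none or still open, it means among the compounds named here.

Of the compounds shown here, three have been measured in a functional assay on cells for antagonist activity at C-C chemokine receptor type 4 (Homo sapiens), read by fluorescence and calcium flux, with stated times of 2.5 s and 45 s; a higher number here means a weaker inhibitor, a lower number a stronger inhibitor. Compound 1 `Cc1nn([C@H](C)c2ccc(Cl)cc2Cl)c2nc(N3CC[C@H](N4CCC[C@H]4C(N)=O)[C@H](C)C3)cnc12` gives 170 nM, compound 2 `Cc1nn([C@H](C)c2ccc(Cl)cc2Cl)c2nc(N3CC[C@H](N4CCC[C@H]4CCS(C)(=O)=O)[C@H](C)C3)cnc12` gives 104 nM, and compound 3 `C[C@@H]1CC(c2cnc3c(C#N)nn([C@H](C)c4ccc(Cl)cc4Cl)c3n2)=CC[C@@H]1N1CCC[C@H]1C(C)(C)O` gives 384 nM, the highest number of the three. Within the data shown here, the only single-point step, a 1.6-fold lower number from compound 1 to compound 2 (0.21 log units; within the scatter), exchanges one group for another on a saturated ring carbon of a different core and stays within the scatter. Compound 4 `C[C@@H]1CC(c2cnc3c(C#N)nn([C@H](C)c4ccc(Cl)cc4Cl)c3n2)=CC[C@@H]1N1CCC[C@H]1C` differs from compound 3 by methyl in place of 1-hydroxy-1-methylethyl on a saturated ring carbon. Among the measured compounds shown here, no measured step removes a 1-hydroxy-1-methylethyl group in this way, so the step from compound 1 to compound 2 bears on it only loosely, as a sign that an exchange on that ring carbon has so far moved the number little. Compound 4 is therefore expected to show a 1.2-fold higher number from compound 3 to compound 4 (0.07 log units; within the scatter), not beyond the scatter. For compound 4 the estimated value is 450 nM, with a range from 150 nM to 1400 nM.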

Compound 4, half-maximal inhibitory concentration: 34 nM
Compound 4: the middle estimate sits 13-fold (1.12 log units) above what was measured; the measured number lies below the stated range.
By their numbers in this assay, from the lowest: compound 4; then compounds 2 and 1 (each within the scatter of the next); then compound 3.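

In this assay the group on this saturated ring carbon, next to the ring nitrogen, turns out to matter greatly: methyl in place of 1-hydroxy-1-methylethyl gives an 11-fold lower number from compound 3 to compound 4 (1.05 log units; beyond the scatter) and lies beyond the scatter. The earlier exchange on such a carbon, a 1.6-fold lower number from compound 1 to compound 2 (0.21 log units; within the scatter), stayed within the scatter and gave no sign of a change this large. Nothing available explains the size of this step. The compounds shown leave open whether the hydroxyl oxygen or the extra carbons account for it; an ethyl or a hydroxymethyl group here would separate the two.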